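The source may hold more compounds than are shown below. What is called first, only, known or untested is meant among the compounds shown, and "the series" means these compounds.

Series so far, in a functional assay on L1210 cells (Mus musculus) for inhibition; a lower number here means a stronger inhibitor, a higher number a weaker inhibitor:
- compound 1 `Nc1nc(O)c2ncn(C/C=C\CO)c2n1`: 680000 nM
- compound 2 `Nc1ccn(C/C=C\CCl)c(=O)n1`: 10000 nM
- compound 3 `Nc1ncnc2c1ncn2C/C=C\CCl`: 22000 nM

Compound 3 has the second highest of the three numbers. Compound 2 lies lower and compound 1 much higher, and both gaps are beyond the scatter.

The next compound is compound 4 `Nc1ncnc2c1ncn2/C=C\CCO`, which departs from compound 3 as follows: 4-hydroxybut-1-en-1-yl in place of 4-chlorobut-2-en-1-yl on an aromatic nitrogen. In words, 4-hydroxybut-1-en-1-yl stands in place of 4-chlorobut-2-en-1-yl on an aromatic nitrogen.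

Among the measured compounds shown here, no measured pair isolates this change, so the data give only indirect guidance. For the measured compounds named here, compound 1, the only measured compound with a chain ending in hydroxy, has the highest number at 680000 nM, but its core also differs from that of compound 3. That is weak support for a move toward weaker inhibition.

In this assay, the expected step is upward and beyond the scatter, estimated as a 4.1-fold higher number from compound 3 to compound 4 (0.61 log units; beyond the scatter). Compound 4 is estimated at 90000 nM, with an expected range of 30000 nM to 300000 nM.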

Compound 4, half-maximal inhibitory concentration: 200000 nM
Estimate against measurement, compound 4: 2.2-fold (0.35 log units) below; the measured number falls inside the stated range.
By their numbers in this assay, from the lowest: compound 2; then compound 3; then compound 4; then compound 1.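

In this assay, among the compounds shown here, the chain on the aromatic nitrogen proves to matter on the shared core: replacing 4-chlorobut-2-en-1-yl with 4-hydroxybut-1-en-1-yl gives a 9.1-fold higher number from compound 3 to compound 4 (0.96 log units; beyond the scatter) as the first step between compounds that differ in one place. The heavy-atom count of the chain stays the same, so this weaker inhibition comes with a change in the chain's end group and double-bond placement, not in its size. No measurement on hand accounts for the step.

The compounds shown leave open whether the step follows the exchange of chlorine for hydroxy or the shift of the double bond, since the two change together here. Also open, as far as these compounds go, is how a chain ending in an amine or a carboxylic acid, or a longer chain, would read at this aromatic nitrogen.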